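Thiazol-2-yl for thiophen-2-yl: working notes

A few compounds are considered here, and "the series" means these few. Any claim that something is new, unique, unknown or untested is made for them only; others in the source may bear on it.

Values in an ADME assay on MRC5 cells (Homo sapiens) for cytotoxicity, read by MTT assay, with a stated time of 72 h; on this read-out higher numbers stand for lower toxicity in this test and lower numbers for higher toxicity in this test:
- compound 1 `OC[C@H]1O[C@@H](n2cc(F)c3c(-c4ccccc4)ncnc32)[C@H](O)[C@@H]1O`: > 50000 nM, a limit of the assay
- compound 2 `OC[C@H]1O[C@@H](n2cc(F)c3c(-c4ccoc4)ncnc32)[C@H](O)[C@@H]1O`: 15400 nM
- compound 3 `OC[C@H]1O[C@@H](n2cc(F)c3c(-c4cccs4)ncnc32)[C@H](O)[C@@H]1O`: 47200 nM

Compound 3 at 47200 nM has the higher of the two actual numbers, and compound 2 is its nearest neighbour. Compound 4 `OC[C@H]1O[C@@H](n2cc(F)c3c(-c4nccs4)ncnc32)[C@H](O)[C@@H]1O` carries 1,3-thiazol-2-yl in place of thiophen-2-yl on an aromatic carbon. Among the measured compounds shown here, no measured step makes this exact exchange. The closest guides are other exchanges of the same group: a 3.1-fold higher number from compound 2 to compound 3 (0.49 log units; beyond the scatter), an at least 3.2-fold lower number from compound 1 to compound 2 (0.51 log units; beyond the scatter) and an at least 1.0-fold lower number from compound 1 to compound 3 (0.02 log units; that floor lies within the scatter). In this assay, a small step towards a lower number is therefore expected, modest at the very most. The expected change is a 1.6-fold lower number from compound 3 to compound 4 (0.20 log units; within the scatter). Compound 4 is estimated at 30000 nM, with a range of 12000 nM to 60000 nM.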

Compound 4, half-maximal cytotoxic concentration: > 50000 nM
Compound 4 gave a limit, no number; the forecaster's own chance of this, stated with the estimate: 30%; middle value at least 1.6-fold (0.22 log units) away from the limit.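

In this assay, compound 4 gives > 50000 nM, a limit of the assay and not a number. Among the compounds shown here, with 1,3-thiazol-2-yl in place of thiophen-2-yl, the result is an at least 1.0-fold higher number from compound 3 to compound 4 (0.02 log units; that floor lies within the scatter), so this change brings no step towards higher toxicity in this test, while the exchange for furan-3-yl gives an at least 3.2-fold higher number from compound 2 to compound 4 (0.51 log units; beyond the scatter). The step between compound 1 and compound 4 cannot be read because both values are limits: the limit of > 50000 nM in this assay, at which 2 of the 4 values shown sit.

Going by these compounds, how far compound 1 and compound 4 lie beyond that limit stays open. Also open, on these data alone, is how an amine or a carboxylic acid on the five-membered ring would read here.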